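Aryl variation on the shared core: compound 2 to compound 3

The compounds below may be only part of what the source reports. "The series", "measured", "known", "first", "only" and "open" are said of these compounds alone.

Two members of the series have been measured in a functional assay on PC-3 cells (Homo sapiens) for antiproliferative activity, read by MTT assay, tested at 5 uM; a lower number here means a weaker effect, a higher number a stronger effect of the compound at the concentration tested. Compound 1 `COc1cc(C2=NN(C(C)=O)C(c3ccc(F)cc3)O2)cc(OC)c1OC` gives 0.1% in this assay. Compound 2 `COc1cc(C2=NN(C(C)=O)C(c3ccc(C(F)(F)F)cc3)O2)cc(OC)c1OC` gives -0.7%. Within the data shown here, the one step between them, a number 0.8 percentage points lower from compound 1 to compound 2 (within the scatter), leaves both numbers close to zero, so neither compound shows an effect at the concentration tested. Compound 2 stands at the bottom of the two numbers shown, with compound 1 within the scatter of it, so the two are not distinguished.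

Among the measured compounds shown here, compound 3 `COc1cc(C2=NN(C(C)=O)C(c3ccc(F)c(F)c3)O2)cc(OC)c1OC` differs from compound 2 at one place: 3,4-difluorophenyl in place of 4-(trifluoromethyl)phenyl on a saturated ring carbon Only the step from compound 1 to compound 2 bears on this change, since it also exchanges one fluorine-bearing aryl group for another on the same saturated ring carbon, and that step was within the scatter. For the measured compounds named here, no measured step has moved this assay beyond the scatter, so no movement beyond the scatter is expected here either. For compound 3 the expected step is a number 0.7 percentage points higher from compound 2 to compound 3 (within the scatter). Compound 3 is estimated at 0% in this assay, in a range from -10% to 10%.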

Compound 3, a percentage reported as inhibition, at one concentration (the size of the read-out at that concentration, not a potency): 46.9%
For compound 3 the middle estimate is 46.9 percentage points below the measured one, and the stated range ends below it.
By their numbers in this assay, from the lowest: compounds 2 and 1 (each within the scatter of the next); then compound 3.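

At the saturated ring carbon of the shared core, the aryl group can set the read-out in this assay: trifluoromethyl in place of fluoro left compounds 1 and 2 undivided, whereas 3,4-difluorophenyl in place of 4-(trifluoromethyl)phenyl gives a number 47.6 percentage points higher from compound 2 to compound 3 (beyond the scatter) and opens the first clear separation in the series. A single change on the aryl ring is enough for this, since fluoro in place of hydrogen on an aromatic carbon gives a number 46.8 percentage points higher from compound 1 to compound 3 (beyond the scatter) and places compound 3 clearly above both other compounds in this assay at the concentration tested. Nothing available here accounts for this jump.

The compounds shown leave open whether the effect depends on fluoro itself or would also appear with chloro, methoxy or a nitrile on the aryl ring in its place. They also leave open how much of the effect survives with an amine or a carboxylic acid on that ring, and whether a read-out at one concentration would carry over to a potency.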